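A Larger Ring on the Ester Oxygen

The source may hold more compounds than are shown below. What is called first, only, known or untested is meant among the compounds shown, and "the series" means these compounds.

Of the compounds shown here, three have been measured in a functional assay on HEK293 cells for antagonist activity at Voltage-dependent L-type calcium channel subunit alpha-1D (Rattus norvegicus), read by FLIPR; a lower number here means a stronger inhibitor, a higher number a weaker inhibitor. Compound 2 `COC(=O)C1=C(C)NC(C)=C(C(=O)OCC2CC2)C1c1cccc([N+](=O)[O-])c1` gives 21 nM in this assay, which places it second highest of the three numbers. Compound 3 `C=C(C)C(=O)OCCOC(=O)C1=C(C)NC(C)=C(C(=O)OCC)C1c1cccc([N+](=O)[O-])c1` gives 10 nM in this assay, and compound 1 `CCOC(=O)C1=C(C)NC(/C=C/C#N)=C(C(=O)OCC)C1c1cccc([N+](=O)[O-])c1` gives 45 nM; both gaps from compound 2 lie beyond the usual scatter. Compound 4 `COC(=O)C1=C(C)NC(C)=C(C(=O)OC2C=CCCC2)C1c1cccc([N+](=O)[O-])c1` has not yet been measured. It differs from compound 2 in one place: cyclohex-2-en-1-yl in place of cyclopropylmethyl on an oxygen next to a carbonyl group. Among the measured compounds shown here, no measured pair isolates a change of this kind, so the data give no direct size for it. The step expected from compound 2 to compound 4 is a 1.1-fold lower number from compound 2 to compound 4 (0.02 log units; within the scatter), none beyond the scatter. Compound 4 is estimated at 20 nM in this assay, with a range from 7 nM to 60 nM.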

Compound 4, half-maximal inhibitory concentration: 10 nM
Compound 4: the middle estimate sits 2.0-fold (0.30 log units) above what was measured; the measured number falls inside the stated range.
By their numbers in this assay, from the lowest: compounds 3 and 4 (each within the scatter of the next); then compound 2; then compound 1.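

In this assay putting cyclohex-2-en-1-yl in place of cyclopropylmethyl on an oxygen next to a carbonyl group gives a 2.1-fold lower number from compound 2 to compound 4 (0.32 log units; beyond the scatter) and so shows that this position accepts a larger carbon ring, with a modest gain rather than a loss. Ring size, carbon count and the double bond all change together in this one step, so it cannot be assigned to any one of them. Nothing measured here explains the gain. Still open, as far as these compounds go, is whether the double bond matters, which a saturated cyclohexyl ring in its place would test. Also open, from the compounds shown here alone, is whether an amine on a longer chain would be accepted on this oxygen.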